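A few compounds are considered here, and "the series" means these few. Any claim that something is new, unique, unknown or untested is made for them only; others in the source may bear on it.

Compound 1 `O=C(O)Cc1sc(C(c2ccc(F)cc2)c2ccc(F)cc2)nc1-c1ccnc(Cl)c1`, compound 2 `O=C(O)Cc1sc(C(c2ccc(F)cc2)c2ccc(F)cc2)nc1-c1ccnc(F)c1` and compound 3 `O=C(O)Cc1sc(C(c2ccc(F)cc2)c2ccc(F)cc2)nc1-c1ccoc1` share one core and differ only in the aromatic group attached to it. In an in vitro functional assay on HEK285-7 cells for antagonist activity at prostaglandin D2 receptor 2 (Homo sapiens), read by BRET and beta-arrestin recruitment (on this read-out lower numbers stand for smaller maximal responses and higher numbers for larger maximal responses), compound 1 gives 80%, compound 2 gives 80% and compound 3 gives 80%. Exchanging fluoro for chloro on an aromatic carbon left the maximal response unchanged, no change at the digits printed from compound 1 to compound 2 (within the scatter), and putting furan-3-yl in place of 2-chloropyridin-4-yl or 2-fluoropyridin-4-yl did the same, no change at the digits printed from compound 1 to compound 3 (within the scatter) and no change at the digits printed from compound 2 to compound 3 (within the scatter). Compound 3 therefore stands level with compounds 1 and 2, all three reaching the same maximal response within the usual scatter.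

Compound 4 `CN(C)c1cc(-c2nc(C(c3ccc(F)cc3)c3ccc(F)cc3)sc2CC(=O)O)ccn1` has not yet been measured. It differs from compound 3 in one place: 2-(dimethylamino)pyridin-4-yl in place of furan-3-yl on an aromatic carbon. The two steps that exchanged the group at this same place both stayed within the scatter, and they are the ones that bear on this change. Because no change at the digits printed from compound 1 to compound 3 (within the scatter) and no change at the digits printed from compound 2 to compound 3 (within the scatter) showed no movement, the expected step in this assay is none beyond the scatter, no change at the digits printed from compound 3 to compound 4 (within the scatter). Compound 4 is estimated at 80%, with a range from 65% to 95%.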

Compound 4, largest response reached (reported as efficacy), in percent of the reference or control that the assay uses: 80%
For compound 4 middle estimate and measured number coincide at the digits printed, and the stated range covers the measured number.
By their numbers in this assay, from the lowest: compounds 1, 2, 3 and 4 (each within the scatter of the next).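

The earlier compounds shown here carried only furan-3-yl or a halogen-bearing pyridinyl group at this place, next to the ring nitrogen. 2-(Dimethylamino)pyridin-4-yl brings 9 heavy atoms where furan-3-yl has 5, yet this assay shows no change at the digits printed from compound 3 to compound 4 (within the scatter), and dimethylamino in place of a halogen gives no change at the digits printed from compound 2 to compound 4 (within the scatter) and no change at the digits printed from compound 1 to compound 4 (within the scatter), so a larger group carrying an amine fits this place with the maximal response held level. No measurement at hand accounts for this flat result.

Going by these compounds, it remains open whether a primary amine, a carboxylic acid or a longer alkyl chain on the pyridinyl ring would shift the response. On these data alone, all four compounds also keep the carboxymethyl group, so what a change there would do is equally open.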